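Bromo in place of hydrogen on the benzylidene phenyl

The compounds below may be only part of what the source reports. "The series", "measured", "known", "first", "only" and "open" are said of these compounds alone.

Measured so far:
compound 1 `Cc1cccc2c1N(CC(=O)O)C/C(=C\c1ccc(F)cc1)C2=O`: 22.9%
compound 2 `Cc1ccc2c(c1)C(=O)/C(=C/c1ccccc1)CN2CC(=O)O`: 4.23%

In an assay on HL-60 cells for inhibition of glutathione S-transferase P (Homo sapiens), read by spectrophotometry, tested at 20 uM (a lower number here means less inhibition, a higher number more inhibition at the concentration tested (going by the name of the read-out)), compound 2 gives 4.23%, the lowest of the two numbers. Among the measured compounds shown here, compound 1 with 22.9% stands higher by a gap beyond the scatter, but the two differ at more than one place, so no single step links them. Compound 3 `Cc1ccc2c(c1)C(=O)/C(=C/c1ccc(Br)cc1)CN2CC(=O)O` differs from compound 2 by bromo in place of hydrogen on an aromatic carbon. For the measured compounds named here, with no measured step of this kind to lean on, the expectation for compound 3 is a small rise, about a number 7.8 percentage points higher from compound 2 to compound 3 (within the scatter), which need not clear the scatter. Compound 3 is thus estimated at 12%, within 0% to 30%.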

Compound 3, a percentage reported as inhibition, at one concentration (the size of the read-out at that concentration, not a potency): 28.2%
For compound 3 the middle estimate is 16.2 percentage points below the measured one; the range from low to high includes it.
By their numbers in this assay, from the lowest: compound 2; then compounds 1 and 3 (each within the scatter of the next).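

Among the compounds shown here, the first single-place step is phenyl to 4-bromophenyl, and in this assay it reads a number 24 percentage points higher from compound 2 to compound 3 (beyond the scatter), on the aromatic carbon para to a large group. This position is therefore not silent in this assay: one bromine atom, with no hydrogen-bond donors or acceptors added, is enough to move the read-out beyond the scatter. No measurement at hand gives a reason for the step.

Open, as far as these compounds go, is whether chloro, methoxy or an amine on this same carbon would move the read-out as bromo does. Also open, from the compounds shown here alone, is whether the step carries over to the core of compound 1.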